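The source may report more compounds than this note shows. Statements on the series, on what has been measured and on what is new or still open speak of the compounds shown alone.

Compound 1 `Cc1cc(C#N)cc(C)c1Oc1nc(Nc2ccc(C#N)cc2)ncc1/C=C/C(=O)NCC1CCN(S(C)(=O)=O)CC1` is the starting point. In an ADME assay on TZM cells (Homo sapiens) for cytotoxicity, with a stated time of 1 days (a lower number here means that less compound is tolerated, a higher number that more compound is tolerated), compound 1 gives > 171 nM, which is a limit of the assay rather than a number. Compound 2 `Cc1cc(C#N)cc(C)c1Oc1nc(Nc2ccc(C#N)cc2)ncc1/C=C/C(=O)NC1CCN(S(=O)(=O)C(F)(F)F)CC1` gives > 160 nM in this assay, again a limit. Compound 3 `Cc1cc(C#N)cc(C)c1Oc1nc(Nc2ccc(C#N)cc2)ncc1/C=C/C(=O)NC1CCN(C(=O)C(F)(F)F)CC1` gives > 170 nM in this assay, also a limit. The steps among them are therefore unreadable: a step that the two limits leave unreadable from compound 1 to compound 3 and a step that the two limits leave unreadable from compound 2 to compound 3. The new compound 4 `Cc1cc(C#N)cc(C)c1Oc1nc(Nc2ccc(C#N)cc2)ncc1/C=C/C(=O)N1CCN(C=O)CC1` differs from compound 1 by 4-formylpiperazin-1-yl in place of ((1-(methylsulfonyl)piperidin-4-yl)methyl)amino on a carbonyl carbon. Since every measured value sits at a limit (the limit of > 160 nM in this assay, at which 1 of the 3 values shown sits, (the limit of > 170 nM in this assay, at which 1 of the 3 values shown sits), (the limit of > 171 nM in this assay, at which 1 of the 3 values shown sits)), no step beyond the scatter can be read, and the expected step that the limit leaves unreadable from compound 1 to compound 4 is likewise only an expectation. Compound 4 is estimated at 400 nM, between 170 nM and 3000 nM.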

Compound 4, half-maximal cytotoxic concentration: > 197 nM
Compound 4: a limit, no number; the forecaster's own chance of this, stated with the estimate: 80%; the middle value is on the limit's open side.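

For the compounds shown here, compound 1 and compound 4 each give only a limit, so no step between them can be read. The compounds shown leave open the actual half-maximal cytotoxic concentration of each compound in this assay.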